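The source may report more compounds than this note shows. Statements on the series, on what has been measured and on what is new or still open speak of the compounds shown alone.

Of the compounds shown here, two built on the same core have been measured. In an assay on isolated protein for inhibition of serine/threonine-protein kinase PAK 1 (Homo sapiens), read by ADP-Glo, with a stated time of 40 min (on this read-out lower numbers stand for stronger inhibition and higher numbers for weaker inhibition), compound 1 (`O=C(NC1CCN(c2ncnc3[nH]ncc23)CC1)c1ccc(Br)cc1`) gives 16400 nM, the higher of the two numbers in hand. Compound 2 (`O=C(NC1CCN(c2ncnc3[nH]ncc23)CC1)c1cccc(C(F)(F)F)c1`) gives 2510 nM in this assay, a gap beyond the usual scatter. Compound 3 (`Cc1ccc(NC(=O)NC2CCN(c3ncnc4[nH]ncc34)CC2)cc1`) has not yet been measured; it differs from compound 1 by (4-methylphenyl)amino in place of 4-bromophenyl on a carbonyl carbon. Among the compounds with values here, no measured pair shows this change, so the expectation rests on little. The step of a 1.8-fold lower number from compound 1 to compound 3 (0.26 log units; within the scatter) is expected to be modest, toward stronger inhibition or none beyond the scatter. Compound 3 is estimated at 9000 nM, within a range from 2500 nM to 32000 nM.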

Compound 3, half-maximal inhibitory concentration: 4710 nM
Compound 3: middle estimate off by 1.9-fold (0.28 log units), on the high side; the range from low to high includes it.
By their numbers in this assay, from the lowest: compounds 2 and 3 (each within the scatter of the next); then compound 1.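

In this assay, the change on the carbonyl carbon gives a 3.5-fold lower number from compound 1 to compound 3 (0.54 log units; beyond the scatter), so this position accepts (4-methylphenyl)amino in place of 4-bromophenyl, with stronger inhibition. The change brings in a nitrogen with one hydrogen-bond donor and removes the bromine in a single step, so its parts cannot be told apart here. No measurement at hand accounts for the shift. Going by these compounds, it remains open whether the shift follows the added amino nitrogen or the methyl in place of bromine, and how a phenylamino group without the methyl, or a carboxylic acid on that ring, would read.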